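The source may hold more compounds than are shown below. What is called first, only, known or untested is meant among the compounds shown, and "the series" means these compounds.

Measured compounds and their results in an ADME assay on BHK cells (Mesocricetus auratus) for cytotoxicity, read by MTT assay, with a stated time of 96 h; on this read-out higher numbers stand for lower toxicity in this test and lower numbers for higher toxicity in this test:

Compound 1, `Fc1ccc(-c2nc3cc(C(F)(F)F)ccc3[nH]2)cc1`: 25000 nM
Compound 2, `CC(=O)Nc1ccc(-c2nc3cc(C(F)(F)F)ccc3n2C2CCCCC2)cc1`: 15000 nM
Compound 3, `Cn1c(-c2ccc(NC(=O)CN3CCCCC3)cc2)nc2cc(C(F)(F)F)ccc21`: > 100000 nM, a limit of the assay rather than a number.

Compound 1 and compound 2 sit within the usual scatter of each other in this assay, so neither is set apart from the other on these numbers. The value of compound 3 is a limit of the assay and gives no number to compare (the limit of > 100000 nM in this assay, at which 1 of the 3 values shown sits). Within the data shown here, with two numbers and one limit, no step between measured compounds that differ in a single place is at hand, so nothing measured shows what a single change on the shared core does to this read-out.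

Compound 4, `O=C(CCl)Nc1ccc(-c2nc3cc(C(F)(F)F)ccc3[nH]2)cc1`, is the one still to be measured in this assay. It differs from compound 1 by ((chloromethyl)carbonyl)amino in place of fluoro on an aromatic carbon. Compound 2 also carries an acylated amino group on its phenyl ring, and compound 3 a further elaborated one. The step from compound 1 to compound 4 is expected to be small and toward a lower number, about a 2.5-fold lower number from compound 1 to compound 4 (0.40 log units; beyond the scatter), since compound 2 with its acetylamino group gives 15000 nM. Compound 4 is therefore estimated at 10000 nM in this assay, with a likely range from 3000 nM to 40000 nM.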

Compound 4, half-maximal cytotoxic concentration: 22000 nM
Compound 4: middle estimate off by 2.2-fold (0.34 log units), on the low side; low and high end bracket the measured number.
By their numbers in this assay, from the lowest: compounds 2, 4 and 1 (each within the scatter of the next). At a limit, above all of these: compound 3.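

In this assay, among these compounds, the first step that can be read at this position is a 1.1-fold lower number from compound 1 to compound 4 (0.06 log units; within the scatter), for ((chloromethyl)carbonyl)amino in place of fluoro on an aromatic carbon, para to a large group. Among the compounds shown here, the earlier compounds offered no single-place comparison, so this is the first sign that the entering group, with 5 heavy atoms against 1 heavy atom and with 1 hydrogen-bond donor and 1 hydrogen-bond acceptor, does not set compound 4 apart from compound 1 on this read-out. Nothing at hand bears on why the two compounds cannot be told apart here.

Compound 3 gives > 100000 nM, a limit of the assay and not a number, and the steps involving compound 2 and compound 3 cannot be read, as each differs from the others in more than one place. Open, as far as these compounds go, is whether another group on this same carbon, such as a primary amine, a carboxylic acid or a longer chain on the carbonyl, would give a step beyond the scatter in this assay.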